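The source may report more compounds than this note shows. Statements on the series, on what has been measured and on what is new or still open speak of the compounds shown alone.

In a functional assay on MDA-MB-231 cells (Homo sapiens) for cytotoxicity, read by MTT assay, with a stated time of 24 h (a higher number here means a weaker inhibitor, a lower number a stronger inhibitor), compound 1 (`NCC(=O)NCc1nnc(-c2ccccc2)o1`) gives 283 nM. For the measured compounds named here, compound 2 (`C[C@@H](N)C(=O)NCc1nnc(-c2ccccc2)o1`) gives 230 nM, and the two numbers lie within the scatter of each other, so compound 1 does not stand apart from its only measured neighbour. Compound 3 (`NCC(=O)NCc1nnc(-c2ccc(F)cc2)o1`) keeps the chain of compound 1 and alters the aromatic ring: fluoro in place of hydrogen on an aromatic carbon, para to a large group. Going by the values given here, no measured compound carries a change on this ring, so the data offer no direct guide to it. Among the compounds with values here, the one measured step, a 1.2-fold lower number from compound 1 to compound 2 (0.09 log units; within the scatter), places a methyl on a saturated chain carbon, elsewhere in the molecule, and it bears on the new change only loosely. With compound 1 at 283 nM and that single step so small, no step beyond the scatter is expected in this assay, and no direction is favoured with any confidence. The expected change is a 1.2-fold lower number from compound 1 to compound 3 (0.07 log units; within the scatter). Compound 3 is estimated at 240 nM, with an expected range from 100 nM to 550 nM.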

Compound 3, half-maximal inhibitory concentration: 254 nM
The estimate for compound 3 lay 1.1-fold (0.02 log units) below the measured number, within the range that was stated.
By their numbers in this assay, from the lowest: compounds 2, 3 and 1 (each within the scatter of the next).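

Compound 3 carries the first change on the aromatic ring among the compounds shown, and in this assay this gives a 1.1-fold lower number from compound 1 to compound 3 (0.05 log units; within the scatter). At this place, on an aromatic carbon, para to a large group, the one added fluorine atom therefore leaves the number within the scatter of compound 1, so the ring position joins the saturated chain carbon, where the methyl gave a 1.2-fold lower number from compound 1 to compound 2 (0.09 log units; within the scatter) in this assay, as a second place where a single small change shifts nothing beyond the scatter. No measurement at hand bears on why the fluoro step came out this way.

As far as these compounds go, it remains open whether another group at this same ring position, such as chloro, methoxy, trifluoromethyl, an amine or a carboxylic acid, would stay within the scatter of compound 1 or move beyond it. Also open, from the compounds shown here alone, is whether the fluoro on the ring and the methyl on the chain, carried together in one compound, would read any differently from compound 1 in this assay.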